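Removing One Nitrogen from the Urea Bridge

A few compounds are considered here, and "the series" means these few. Any claim that something is new, unique, unknown or untested is made for them only; others in the source may bear on it.

Of the compounds shown here, two have been measured in a functional assay on A549 cells (Homo sapiens) for inhibition, read by sulforhodamine B assay, with a stated time of 48 h, tested at 100 uM; a higher number here means a weaker effect of the compound at the concentration tested, a lower number a stronger effect. Compound 1 `COc1cc(Cl)cc(-c2nn(-c3cccc(NC(=O)Nc4ccc(Cl)c(C(F)(F)F)c4)c3)cc2-c2ccncc2)c1` gives -76%. Compound 2 `COc1cc(Cl)cc(-c2nn(-c3cccc(NC(=O)Nc4cccc(C(F)(F)F)c4)c3)cc2-c2ccncc2)c1` gives -24%, the highest of the two numbers, so it shows the weaker effect in this assay. Going by the values given here, the one measured step, a number 52 percentage points higher from compound 1 to compound 2 (beyond the scatter), concerns hydrogen in place of chloro on an aromatic carbon.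

Compound 3 `COc1cc(Cl)cc(-c2nn(-c3cccc(NC(=O)c4cccc(C(F)(F)F)c4)c3)cc2-c2ccncc2)c1` is not yet measured. It differs from compound 2 by 3-(trifluoromethyl)phenyl in place of (3-(trifluoromethyl)phenyl)amino on a carbonyl carbon. Among the compounds with values here, no measured step touches the carbonyl carbon or the amide-type nitrogen, so the single known step gives no guide to this change. With nothing to build on beyond the value of compound 2 in this assay, compound 3 is expected to land near compound 2, with a step of a number 4 percentage points higher from compound 2 to compound 3 (within the scatter) that may well stay within the scatter. The estimate for compound 3 is therefore -20%, with a range from -70% to 30%.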

Compound 3, a percentage reported as activity, at one concentration (the size of the read-out at that concentration, not a potency): 30%
Compound 3: middle estimate off by 50 percentage points, on the low side; measured number inside the range.
By their numbers in this assay, from the lowest: compound 1; then compound 2; then compound 3.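

Replacing (3-(trifluoromethyl)phenyl)amino with 3-(trifluoromethyl)phenyl on the carbonyl carbon is the first change shown at this position, and in this assay it gives a number 54 percentage points higher from compound 2 to compound 3 (beyond the scatter), so the effect weakens clearly when the nitrogen and its hydrogen-bond donor leave. Compared with the chlorinated urea, the same amide gives a number 106 percentage points higher from compound 1 to compound 3 (beyond the scatter), the widest gap among the three compounds, which leaves compound 3 with the weakest effect of the set. Nothing measured here explains why this change matters so much.

Still open, on these data alone, is whether the chloro group on the aromatic ring would strengthen the effect of the amide as it does for the urea. An oxygen atom or a methylene group in place of the lost nitrogen would test whether the effect depends on that nitrogen specifically.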